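The source may report more compounds than this note shows. Statements on the series, on what has been measured and on what is new or still open speak of the compounds shown alone.

Measured so far:
compound 1 `CN(C)C1(Cc2ccccc2)CCN(c2cc(C(F)(F)F)ccc2CNC(=O)Nc2cccc3c2CC(O)CC3)CC1` — 10.1 nM
compound 2 `CN(C)C1(Cc2ccccc2)CCN(c2cc(C(F)(F)F)ccc2CNC(=O)Nc2ccc3cnccc3c2)CC1` — 156 nM

For the measured compounds named here, in an assay on CHO cells for antagonist activity at transient receptor potential cation channel subfamily V member 1 (Homo sapiens), read by scintillation counting, with a stated time of 5 min, in the presence of a further agent that is not named here (a lower number here means that less compound is needed, a higher number that more compound is needed for the effect), compound 2 gives 156 nM, the higher of the two numbers so far; compound 1 gives 10.1 nM, and the step of a 15-fold higher number from compound 1 to compound 2 (1.19 log units; beyond the scatter) is the only measured step in the set. Compound 3 `CN(C)C1(Cc2ccccc2)CCN(c2cc(C(F)(F)F)ccc2CNC(=O)Nc2cccc3ccncc23)CC1` is the unmeasured member. It differs from compound 2 by isoquinolin-8-yl in place of isoquinolin-6-yl on an amide-type nitrogen. Going by the values given here, no measured step covers this exchange of one isoquinolinyl for another on the amide-type nitrogen; the single step from compound 1 to compound 2 shows only that the group on that nitrogen can move the number by a large amount, not in which direction a change of the attachment point within the isoquinolinyl would act. The expectation for compound 3 is therefore uncertain in sign, and the estimated step of a 2.0-fold lower number from compound 2 to compound 3 (0.29 log units; within the scatter) is set close to compound 2 with a wide range. Compound 3 is estimated at 80 nM in this assay, expected between 15 nM and 400 nM.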

Compound 3, half-maximal effective concentration: 18.7 nM
Estimate against measurement, compound 3: 4.3-fold (0.63 log units) above; the measured number falls inside the stated range.
By their numbers in this assay, from the lowest: compounds 1 and 3 (each within the scatter of the next); then compound 2.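

In this assay, moving the attachment point from isoquinolin-6-yl to isoquinolin-8-yl on the amide-type nitrogen gives an 8.3-fold lower number from compound 2 to compound 3 (0.92 log units; beyond the scatter); the atoms and the counted features of the group stay the same, so at this position the attachment point alone carries a step beyond the scatter. Exchanging 3-hydroxy-1,2,3,4-tetrahydronaphthalen-5-yl for isoquinolin-8-yl gives a 1.9-fold higher number from compound 1 to compound 3 (0.27 log units; within the scatter), which lies within the scatter, so the large step of a 15-fold higher number from compound 1 to compound 2 (1.19 log units; beyond the scatter) does not follow from the presence of an isoquinolinyl group as such but holds for isoquinolin-6-yl only. No measurement at hand bears on why the attachment point makes this difference.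

The compounds shown leave open how other attachment points, such as isoquinolin-5-yl or isoquinolin-7-yl, would read on the same nitrogen. They also leave open what the ring nitrogen of isoquinolin-8-yl and the hydroxy group of compound 1 each contribute, a question that a naphthalen-1-yl group and a tetrahydronaphthalenyl group without the hydroxy group on the same core could address.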